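Swapping a thiazole amide for a halogenated phenyl amide

The source may report more compounds than this note shows. Statements on the series, on what has been measured and on what is new or still open speak of the compounds shown alone.

Measured compounds:
compound 1 `O=C(Nc1ccc(Cl)c(-c2nnc3c(Cl)cccn23)c1)c1ccc(C(F)(F)F)cc1F` — 70800 nM
compound 2 `CS(=O)(=O)c1ccc(C(=O)Nc2ccc(Cl)c(-c3nnc4c(Cl)cccn34)c2)c(Cl)c1` — > 100000 nM
compound 3 `Cc1nc(C(=O)Nc2ccc(Cl)c(-c3nnc4c(Cl)cccn34)c2)cs1` — > 100000 nM

Three amides sharing the core of compound 1 have been tested in a functional assay on T47D cells (Homo sapiens) for antiproliferative activity, read by MTT assay, with a stated time of 72 h; a higher number here means a weaker inhibitor, a lower number a stronger inhibitor. Compound 1 gives 70800 nM in this assay. For compound 2 this assay reports only a limit, > 100000 nM, and not a number. Compound 3 likewise reaches only a limit, > 100000 nM. Compound 3 therefore stands at the weak end of what is shown, and because of the limit of > 100000 nM in this assay, at which 2 of the 3 values shown sit, it cannot be ranked against compound 2 at all; only compound 1 returns an actual number.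

Compound 4 `O=C(Nc1ccc(Cl)c(-c2nnc3c(Cl)cccn23)c1)c1c(F)cccc1Cl` has not yet been measured in this assay. It differs from compound 3 in one place: 2-chloro-6-fluorophenyl in place of 2-methyl-1,3-thiazol-4-yl on a carbonyl carbon. Within the data shown here, no step between two measured compounds isolates this change, so any expectation rests on the three values alone. Among the measured compounds shown here, compound 1, the one amide bearing a six-membered carbon-only aromatic ring, is the only one with a number, and that number is itself weak.

Compound 4 is therefore expected to sit near the weak end as well, with an estimated value of 65000 nM (range 20000 nM to 200000 nM). The estimated step of an at least 1.5-fold lower number from compound 3 to compound 4 (0.18 log units; that floor lies within the scatter) is expected to be small, if anything a modest gain that may not exceed the scatter.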

Compound 4, half-maximal inhibitory concentration: > 100000 nM
Compound 4: a limit, no number; the forecaster's own chance of this, stated with the estimate: 45%; middle value at least 1.5-fold (0.18 log units) from the limit.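

In this assay compound 4 reaches only a limit, > 100000 nM. Among these compounds, no step from compound 3 to compound 4 can be read, because both compounds end at the same limit: the limit of > 100000 nM in this assay, at which 3 of the 4 values shown sit. Whether 2-chloro-6-fluorophenyl in place of 2-methyl-1,3-thiazol-4-yl on a carbonyl carbon changes antiproliferative activity at all remains open.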